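The source may hold more compounds than are shown below. What is called first, only, known or untested is meant among the compounds shown, and "the series" means these compounds.

The measured compounds:
- compound 1, `Cc1nc(-c2ccc(Cl)cc2)c(CC(=O)O)s1`, in an in vitro functional assay on HEK285-7 cells for antagonist activity at prostaglandin D2 receptor 2 (Homo sapiens), read by BRET and beta-arrestin recruitment (on this read-out lower numbers stand for stronger inhibition and higher numbers for weaker inhibition), compound 1 gives 41000 nM
- compound 2, `O=C(O)Cc1sc(C(c2ccccc2)c2ccccc2)nc1-c1ccccc1`, compound 2 gives 370 nM
- compound 3, `O=C(O)Cc1sc(C(c2ccccc2)c2ccccc2)nc1-c1ccc(F)c(F)c1`, compound 3 gives 43 nM

Compound 3 has the lowest number of the three. Among the compounds with values here, its nearest neighbour is compound 2, and the only single change that can be read from the measured set is the one between them: an 8.6-fold lower number from compound 2 to compound 3 (0.93 log units; beyond the scatter). Compound 1 lies far above both.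

Compound 4, `COc1ccc(OC)c(-c2nc(C(c3ccccc3)c3ccccc3)sc2CC(=O)O)c1`, is not yet measured. It differs from compound 3 in one place: 2,5-dimethoxyphenyl in place of 3,4-difluorophenyl on an aromatic carbon. Within the data shown here, the only measured step that touches the same ring is the one from compound 2 to compound 3, and that step put two fluorines onto a phenyl ring, a change of a different kind from what compound 4 carries. The data give no direct guide for methoxy groups at these positions, so the expectation for compound 4 leans on the spread between compound 2 and compound 3 rather than on a matching step.

The estimate for compound 4 is a number higher than that of compound 3, roughly a 7.0-fold higher number from compound 3 to compound 4 (0.84 log units; beyond the scatter), with wide uncertainty. Compound 4 is expected to give about 300 nM, within a range from 60 nM to 1500 nM.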

Compound 4, half-maximal inhibitory concentration: > 100000 nM
Compound 4: a limit, no number; the forecaster's own chance of this, stated with the estimate: 5%; middle value at least 330-fold (2.52 log units) away from the limit.
By their numbers in this assay, from the lowest: compound 3; then compound 2; then compound 1. At a limit, above all of these: compound 4.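

In this assay compound 4 gives no number but a limit of the assay, the only one among the compounds shown: the limit of > 100000 nM in this assay, at which 1 of the 4 values shown sits.

Up to this point, the one readable change on the ring at this position, on the aromatic carbon next to the ring nitrogen, had lowered the number, and the new result shows that a change at the same ring can also push it sharply the other way: an at least 2300-fold higher number from compound 3 to compound 4 (3.36 log units; beyond the scatter). The rise is not simply the loss of the two fluorines, since the 2,5-dimethoxyphenyl group also stands far from the bare phenyl ring: an at least 270-fold higher number from compound 2 to compound 4 (2.43 log units; beyond the scatter). Substitution on this ring therefore moves the read-out in either direction, depending on which groups it carries, while the rest of the molecule stays the same.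

Compound 4 carries both methoxy groups at once, so the compounds shown do not tell whether a phenyl ring with a single methoxy group would behave the same way, or which of the two groups accounts for the change. They also leave open how smaller groups on this ring, such as a methyl, a chlorine or a hydroxyl, would read in this assay.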